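Benzyl amide variation on the shared core

A few compounds are considered here, and "the series" means these few. Any claim that something is new, unique, unknown or untested is made for them only; others in the source may bear on it.

Measured compounds:
compound 1 `Cc1ccccc1CNC(=O)c1nc(-c2ccc(F)cc2)n(CC[C@@H](O)C[C@@H](O)CC(=O)O)c1C1CC1` gives 4.9 nM in an assay on microsomes from liver for inhibition of 3-hydroxy-3-methylglutaryl-coenzyme A reductase (Rattus norvegicus), read by scintillation counting, with stated times of 0.5 h and 0.75 h; on this read-out higher numbers stand for weaker inhibition and lower numbers for stronger inhibition
compound 2 `O=C(O)C[C@H](O)C[C@H](O)CCn1c(-c2ccc(F)cc2)nc(C(=O)NCc2ccc(F)c(F)c2)c1C1CC1` gives 1.2 nM in this assay

For the measured compounds named here, compound 2 holds the lower of the two numbers so far; the step of a 4.1-fold lower number from compound 1 to compound 2 (0.61 log units; beyond the scatter) lies beyond the scatter, so compound 2 is the stronger inhibitor of the pair on these data.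

Compound 3 `O=C(O)C[C@H](O)C[C@H](O)CCn1c(-c2ccc(F)cc2)nc(C(=O)NCc2ccc(F)cc2)c1C1CC1` differs from compound 2 by hydrogen in place of fluoro on an aromatic carbon of the six-membered ring of carbon only, ortho to the remaining fluoro group and meta to the large group; read one bond further out, 3,4-difluorobenzyl becomes 4-fluorobenzyl.

Going by the values given here, only one measured step exists, a 4.1-fold lower number from compound 1 to compound 2 (0.61 log units; beyond the scatter), and it exchanges the whole 2-methylphenyl for 3,4-difluorophenyl, so it does not isolate the single fluoro being removed here. Among the compounds with values here, no measured pair shows the effect of one aromatic fluoro alone. The expectation for compound 3 is therefore a step of a 1.8-fold higher number from compound 2 to compound 3 (0.26 log units; within the scatter) that stays within the scatter, if anything a slightly higher number than compound 2. Compound 3 is estimated at 2.2 nM, with a range from 0.9 nM to 5.5 nM.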

Compound 3, half-maximal inhibitory concentration: 3.4 nM
For compound 3 the middle estimate is 1.5-fold (0.19 log units) below the measured one; measured number inside the range.
By their numbers in this assay, from the lowest: compound 2; then compounds 3 and 1 (each within the scatter of the next).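

Within this assay, taking away one fluoro from the aromatic carbon ortho to the remaining fluoro group, so that 3,4-difluorobenzyl becomes 4-fluorobenzyl, gives a 2.8-fold higher number from compound 2 to compound 3 (0.45 log units; beyond the scatter) and is the first reading of this single aromatic carbon on its own. The change from 2-methylphenyl to 4-fluorophenyl on the same saturated chain carbon gives a 1.4-fold lower number from compound 1 to compound 3 (0.16 log units; within the scatter) and leaves compound 1 and compound 3 indistinguishable on these data, so the step from compound 2 to compound 3 shows that hydrogen in place of this one fluoro is enough to give up a measurable part of the advantage of the 3,4-difluorophenyl amide. No measurement on the compounds speaks to why this fluoro changes the number.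

Open, going by these compounds, is whether a chloro, methoxy or trifluoromethyl group on that same aromatic carbon would match or go past compound 2 at 1.2 nM in this series. Also open is what the remaining fluoro contributes, since the unsubstituted benzyl amide and a benzyl amide bearing only the fluoro on the carbon studied here do not stand among the compounds shown.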